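Working notes: chloro in place of butoxy

A few compounds are considered here, and "the series" means these few. Any claim that something is new, unique, unknown or untested is made for them only; others in the source may bear on it.

Measured in a functional assay on MT4 cells (Homo sapiens) for cytotoxicity; on this read-out lower numbers stand for stronger inhibition and higher numbers for weaker inhibition
compound 1 `CCCCOc1cc(C)cc(S(=O)(=O)c2cccc(N)c2C#N)c1` gives > 2000 nM
compound 2 `N#Cc1c(N)cccc1S(=O)(=O)c1ccc(Br)cc1` gives > 200000 nM

Within the data shown here, both entries are limits, so no measured step connects the two compounds. Compound 1 stands at a limit (> 2000 nM) and not at a number, which leaves its true position in this assay open. Compound 3 `Cc1cc(Cl)cc(S(=O)(=O)c2cccc(N)c2C#N)c1` keeps the core of compound 1, with chloro in place of butoxy on an aromatic carbon, meta to a large group and meta to a methyl group (chloro in place of butoxy on an aromatic carbon). An estimated step that the limit leaves unreadable from compound 1 to compound 3 is expected towards higher numbers, meaning weaker inhibition. That expectation leans on compound 2 (> 200000 nM), which has no butoxy and also reports only a limit. For compound 3 the estimated value is 40000 nM (expected range 6000 nM to 200000 nM).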

Compound 3, half-maximal inhibitory concentration: > 200000 nM
Compound 3 ended at the assay's limit (the forecaster's own chance of this, stated with the estimate: 55%); at least 5.0-fold (0.69 log units) between middle value and limit.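

In this assay compound 1 stands at a limit, > 2000 nM. Among these compounds, compound 3 also stands at a limit, > 200000 nM, and no step between compound 1 and compound 3 can be read. The compounds shown leave open where the true values lie, and whether chloro in place of butoxy shifts this read-out at all.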